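The source may hold more compounds than are shown below. What is called first, only, known or untested is meant among the compounds shown, and "the series" means these compounds.

Measured compounds:
Compound 1 `CC(C)n1nc(S(=O)(=O)c2cccc3ccccc23)c2cc(N3CCN(C)CC3)ccc21` gives 1.8 nM in an assay on HeLa cells for displacement of a labelled ligand from 5-hydroxytryptamine receptor 6 (Homo sapiens); a lower number here means a stronger inhibitor, a higher number a weaker inhibitor.
Compound 2 `CN1CCN(c2ccc3c(c2)c(S(=O)(=O)c2cccc4ccccc24)nn3Cc2ccccc2)CC1` gives 2 nM in this assay.
Compound 3 `O=S(=O)(c1cccc(F)c1)c1n[nH]c2cccc(N3CCNCC3)c12` gives 134 nM in this assay.

Compound 3 has the highest number of the three, which means it is the weakest inhibitor of this set. Going by the values given here, the only measured step, a 1.1-fold higher number from compound 1 to compound 2 (0.05 log units; within the scatter), concerns the group on an aromatic nitrogen and stays within the scatter. Compound 4 `Cc1ccc(S(=O)(=O)c2n[nH]c3cccc(N4CCNCC4)c23)cc1` has not yet been measured. It differs from compound 3 by 4-methylphenyl in place of 3-fluorophenyl on a sulfonyl sulfur. Among the compounds with values here, no measured step touches the aryl group on the sulfonyl sulfur, so nothing in the data points to a change in either direction. For compound 4 the number in this assay is therefore expected near that of compound 3, at 120 nM with a range from 40 nM to 400 nM; the expected step of a 1.1-fold lower number from compound 3 to compound 4 (0.05 log units; within the scatter) lies within the scatter.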

Compound 4, inhibition constant: 134 nM
Compound 4: middle estimate off by 1.1-fold (0.05 log units), on the low side, within the range that was stated.
By their numbers in this assay, from the lowest: compounds 1 and 2 (each within the scatter of the next); then compounds 3 and 4 (each within the scatter of the next).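

Exchanging 3-fluorophenyl for 4-methylphenyl on a sulfonyl sulfur gives no change at the digits printed from compound 3 to compound 4 (within the scatter) in this assay. Going by these compounds alone, the earlier step concerned only the group on an aromatic nitrogen, so this is the first view of the aryl group on the sulfur: here, moving from a fluorine-bearing to a methyl-bearing phenyl ring leaves the reading unmoved. No available data explain why these two groups read alike. The compounds shown leave open how a phenyl ring carrying an amine or a carboxylic acid would read at this position.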